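Bromo to Chloro: Estimating the Inhibition of Compound 4

The source may hold more compounds than are shown below. What is called first, only, known or untested is meant among the compounds shown, and "the series" means these compounds.

Compound 1 `O=C(/C=C/c1cccc(F)c1)c1ccc(-n2ccnc2)cc1` reaches only a limit of the assay, > 10000 nM, in an assay on isolated protein for inhibition of Amine oxidase [flavin-containing] B (Homo sapiens); on this read-out higher numbers stand for weaker inhibition and lower numbers for stronger inhibition.
Compound 2 `O=C(/C=C/c1ccc(Br)cc1)c1ccc(-n2ccnc2)cc1` gives 320 nM in this assay.
Compound 3 `CCOc1ccc(C(=O)/C=C/c2ccc(Br)cc2)cc1` gives 210 nM in this assay.

Compound 3 holds the lower of the two numbers, but its gap to compound 2, a 1.5-fold lower number from compound 2 to compound 3 (0.18 log units; within the scatter), is within the scatter. Compound 4 `CCOc1ccc(C(=O)/C=C/c2ccc(Cl)cc2)cc1` differs from compound 3 by chloro in place of bromo on an aromatic carbon. Within the data shown here, no measured step isolates this swap. Among the measured compounds shown here, the only step touching the halogen, an at least 31-fold lower number from compound 1 to compound 2 (1.49 log units; beyond the scatter), changes both the halogen and where it sits, so it does not show what the halogen alone does. With one halogen replaced by another at the same place, a step no larger than the scatter is expected for compound 4, a 1.4-fold higher number from compound 3 to compound 4 (0.15 log units; within the scatter). Compound 4 is therefore estimated at 300 nM, ranging from 120 nM to 800 nM.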

Compound 4, half-maximal inhibitory concentration: 210 nM
Compound 4: the middle estimate sits 1.4-fold (0.15 log units) above what was measured; low and high end bracket the measured number.
By their numbers in this assay, from the lowest: compounds 3, 4 and 2 (each within the scatter of the next). At a limit, above all of these: compound 1.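

Until now the halogen had changed only together with its place on the ring. Here it changes alone, on an aromatic carbon para to a large group, and chloro in place of bromo gives no change at the digits printed from compound 3 to compound 4 (within the scatter) in this assay, so bromine is not needed at this place in compounds carrying the ethoxy group. Nothing measured for these compounds explains why the two halogens match.

As far as these compounds go, whether this holds beyond halogens stays open: a methyl group or an amine at the same place could keep the number or lose it.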